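The compounds below may be only part of what the source reports. "The series", "measured", "known", "first", "only" and "open" are said of these compounds alone.

Measured so far:
- compound 1, `CC(C)C[C@H](N)CN(C(=O)C(C)Cc1ccccc1)c1ccc(-c2ccccc2)cc1`: in a functional assay for agonist activity at G protein-coupled receptor 88 (Homo sapiens), read by HTRF and cAMP accumulation (a higher number here means that more compound is needed for the effect, a lower number that less compound is needed), compound 1 gives 1.2 nM
- compound 2, `CN[C@@H](CC(C)C)CN(C(=O)[C@@H]1C[C@H]1c1ccccc1)c1ccc(-c2ccccc2)cc1`: in this assay compound 2 gives 2 nM
- compound 3, `CC[C@H](C)[C@H](N)CN(C(=O)[C@@H]1C[C@H]1c1ccc(F)cc1)c1ccc(-c2ccccc2)cc1`: in this assay compound 3 gives 600 nM

Of the three compounds measured, compound 3 has the highest number in this assay, so it needs the most compound for the effect. Its gap to compound 2 and its gap to compound 1 are both far beyond the scatter of the measurement, so compound 3 is clearly the weakest of the three on this reading. Compound 1 and compound 2 differ from compound 3 in more than one place, so no single change can be held responsible for the difference.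

The next compound, compound 4, `CC[C@H](C)[C@H](N)CN(C(=O)[C@@H]1C[C@H]1c1ncc(C)s1)c1ccc(-c2ccccc2)cc1`, keeps everything in compound 3 but one group on the three-membered ring:

5-methyl-1,3-thiazol-2-yl in place of 4-fluorophenyl on a saturated ring carbon

Among the measured compounds shown here, no pair among the measured compounds shows what this kind of swap does, so there is no step to lean on. For the measured compounds named here, with only the shared core and the single exchange to go on, the expectation is a step of modest size at most, in either direction, quite possibly none beyond the scatter, giving a 1.2-fold lower number from compound 3 to compound 4 (0.08 log units; within the scatter) as the estimated step. On that basis compound 4 is expected to give about 500 nM in this assay, most likely between 100 nM and 3000 nM.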

Compound 4, half-maximal effective concentration: 1300 nM
For compound 4 the middle estimate is 2.6-fold (0.41 log units) below the measured one; low and high end bracket the measured number.
By their numbers in this assay, from the lowest: compounds 1 and 2 (each within the scatter of the next); then compound 3; then compound 4.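

Among the compounds shown here, replacing 4-fluorophenyl with 5-methyl-1,3-thiazol-2-yl on the three-membered ring gives the first comparison here in which only one place changes, and it produces a 2.2-fold higher number from compound 3 to compound 4 (0.34 log units; beyond the scatter) in this assay as a modest loss. This saturated ring carbon therefore tolerates a five-membered aromatic ring with two hetero atoms in place of a six-membered aromatic ring of carbon only, although the compound then needs somewhat more material for the same effect. No measurement shown accounts for this rise, so the step can be recorded but not explained.

The compounds shown do not separate the contribution of the ring from that of its methyl group, a question that the unsubstituted 1,3-thiazol-2-yl group or a 4-methylphenyl group could help to settle. On these data alone, it also remains open whether the same exchange would give a step of similar size in a compound with the amine side chain of compound 2, or whether a pyridin-2-yl group would be tolerated equally well at this position.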